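Moving a Hydroxyl Group: Expected Effect on Topoisomerase Inhibition

The compounds below may be only part of what the source reports. "The series", "measured", "known", "first", "only" and "open" are said of these compounds alone.

Compound 1 `Oc1cccc(-c2cc(-c3cccs3)cc(-c3ccccc3O)n2)c1` gives 1.5% in an assay on isolated protein for inhibition of DNA topoisomerase 1 (Homo sapiens), with a stated time of 30 min, tested at 20 uM; a lower number here means a weaker effect, a higher number a stronger effect of the compound at the concentration tested.
Compound 2 `Oc1ccc(-c2cc(-c3cccs3)cc(-c3ccccc3O)n2)cc1` gives 2% in this assay.
Compound 3 `Oc1cccc(-c2cc(-c3ccco3)cc(-c3ccccc3O)n2)c1` gives 0% in this assay.

All three share a core carrying a 2-hydroxyphenyl group, a second hydroxyphenyl group and one five-membered ring; they differ only in which hydroxyphenyl and which five-membered ring are attached. Compound 4 `Oc1ccc(-c2cc(-c3ccco3)cc(-c3ccccc3O)n2)cc1` has not yet been measured. It differs from compound 3 by 4-hydroxyphenyl in place of 3-hydroxyphenyl on an aromatic carbon. The same change has been made once already, from compound 1 to compound 2: 4-hydroxyphenyl in place of 3-hydroxyphenyl on an aromatic carbon. There the step was a number 0.5 percentage points higher from compound 1 to compound 2 (within the scatter). The two cores are not identical: compound 3 differs from compound 1 by furan-2-yl in place of thiophen-2-yl on an aromatic carbon, with a step of a number 1.5 percentage points lower from compound 1 to compound 3 (within the scatter). The surroundings of the exchanged group are described differently, meta to a thiophen-2-yl group in one case and meta to a furan-2-yl group in the other, so the change leading to compound 4 is the same kind of change, not the same one. For compound 4 a step of a number 1 percentage points higher from compound 3 to compound 4 (within the scatter) is expected. This rests on the earlier step of a number 0.5 percentage points higher from compound 1 to compound 2 (within the scatter) and on the starting value of compound 3, 0%. Compound 4 is therefore estimated at 1%, with a range from -5% to 8%.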

Compound 4, a percentage reported as inhibition, at one concentration (the size of the read-out at that concentration, not a potency): 0%
Estimate against measurement, compound 4: 1 percentage points above; the measured number falls inside the stated range.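

Exchanging 3-hydroxyphenyl for 4-hydroxyphenyl next to the furan-2-yl compounds' shared core gives, in this assay, no change at the digits printed from compound 3 to compound 4 (within the scatter), and this matches what the exchange did alongside thiophen-2-yl: the same change on two cores in this assay, a number 0.5 percentage points higher (within the scatter) from compound 1 to compound 2 and no change at the digits printed (within the scatter) from compound 3 to compound 4, 0.5 percentage points apart, within the scatter of two such steps. Exchanging thiophen-2-yl for furan-2-yl gives a number 2 percentage points lower from compound 2 to compound 4 (within the scatter), and this change also reads alike on both cores: the same change on two cores in this assay, a number 1.5 percentage points lower (within the scatter) from compound 1 to compound 3 and a number 2 percentage points lower (within the scatter) from compound 2 to compound 4, 0.5 percentage points apart, within the scatter of two such steps. Within the data shown here, all four compounds read close to zero, so the series shows only that neither change produces a visible effect at the tested concentration on these cores; it does not show that a change with a real effect would carry from one core to another.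

The compounds shown leave open whether any group in this series can raise the read-out, for example an amine or a carboxylic acid in place of the hydroxyl on the hydroxyphenyl group. The 2-hydroxyphenyl group is also the same throughout, so its contribution cannot be judged from these four compounds.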